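The source may report more compounds than this note shows. Statements on the series, on what has been measured and on what is new or still open speak of the compounds shown alone.

Compound 1 `O=C(/C=C/c1ccc(N2CCCCC2)cc1)c1cccs1` gives 11600 nM in an ADME assay on CCRF-CEM cells (Homo sapiens) for cytotoxicity, with a stated time of 5 days; on this read-out higher numbers stand for weaker inhibition and lower numbers for stronger inhibition.
Compound 2 `Cc1ccsc1C(=O)/C=C/c1ccc(N2CCCCC2)cc1` gives 9900 nM in this assay.
Compound 3 `c1csc(C2=NNC(c3ccc(N4CCCCC4)cc3)C2)c1` gives 6900 nM in this assay.

Compound 3 has the smallest number of the three, yet its gaps to compound 2 and to compound 1 both lie within the usual scatter, so the three cannot be told apart on these data. Compound 4 `c1cc(C2=NNC(c3ccc(N4CCCCC4)cc3)C2)cs1` differs from compound 3 by thiophen-3-yl in place of thiophen-2-yl on a carbon with a double bond to nitrogen. Among the measured compounds shown here, no measured step involves this change. For the measured compounds named here, the only measured step, a 1.2-fold lower number from compound 1 to compound 2 (0.07 log units; within the scatter), is a small change on an aromatic ring and stays within the scatter, so in this assay a similarly small step is expected, with no clear direction. The step expected for this change is a 1.0-fold higher number from compound 3 to compound 4 (0.01 log units; within the scatter). Compound 4 is therefore estimated at 7000 nM, within a range from 3500 nM to 14000 nM.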

Compound 4, half-maximal inhibitory concentration: 27000 nM
For compound 4 the middle estimate is 3.9-fold (0.59 log units) below the measured one, and the stated range ends below it.
By their numbers in this assay, from the lowest: compounds 3, 2 and 1 (each within the scatter of the next); then compound 4.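

Replacing thiophen-2-yl with thiophen-3-yl keeps the same atoms and the same counts of donors and acceptors, yet it gives a 3.9-fold higher number from compound 3 to compound 4 (0.59 log units; beyond the scatter) in this assay, a step beyond the scatter. The number at this position therefore depends on how the thiophene is joined to the carbon with a double bond to nitrogen, not only on which atoms are present. Nothing measured here accounts for this difference.

As far as these compounds go, whether the same swap has a similar effect on the core of compound 1 stays open. So does the outcome with a phenyl group or a furan-2-yl group at this position.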